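Swapping a 4-chlorophenyl for hydroxy on the shared core

The compounds below may be only part of what the source reports. "The series", "measured", "known", "first", "only" and "open" are said of these compounds alone.

Compound 2 `OC[C@H]1C[C@@H](Cn2cnc3c(-c4ccc(Cl)cc4)ncnc32)c2ccccc21` gives 0.63 ug/mL in a functional assay on CCRF-CEM cells (Homo sapiens) (on this read-out lower numbers stand for stronger inhibition and higher numbers for weaker inhibition), the lowest of the three numbers measured. Compound 3 `Cn1ncc2c1[C@H](Cn1cnc3c(Cl)nc(N)nc31)C[C@@H]2CO` gives 3.2 ug/mL in this assay, and compound 1 `Nc1ncnc2c1ncn2C[C@@H]1C[C@H](CO)c2ccccc21` gives 24 ug/mL. Compound 4 `OC[C@H]1C[C@@H](Cn2cnc3c(O)ncnc32)c2ccccc21` has not yet been measured; it differs from compound 2 by hydroxy in place of 4-chlorophenyl on an aromatic carbon. Among the measured compounds shown here, the only measured step that bears on this change is a 38-fold lower number from compound 1 to compound 2 (1.58 log units; beyond the scatter), where a 4-chlorophenyl entered in place of amino at the same aromatic carbon and the number fell sharply. Removing that 4-chlorophenyl again, now for hydroxy, is therefore expected to undo most of that gain, giving a 48-fold higher number from compound 2 to compound 4 (1.68 log units; beyond the scatter). For compound 4 the estimate in this assay is 30 ug/mL, within the range 8 ug/mL to 100 ug/mL.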

Compound 4, half-maximal inhibitory concentration: 24 ug/mL
Compound 4: middle estimate off by 1.3-fold (0.10 log units), on the high side; the range from low to high includes it.
By their numbers in this assay, from the lowest: compound 2; then compound 3; then compounds 1 and 4 (each within the scatter of the next).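

In this assay, hydroxy in place of 4-chlorophenyl gives a 38-fold higher number from compound 2 to compound 4 (1.58 log units; beyond the scatter), so the low number is lost whether amino or hydroxy takes the place of that group. Hydroxy in place of amino gives no change at the digits printed from compound 1 to compound 4 (within the scatter), so these two groups cannot be told apart at this aromatic carbon, and of the three groups seen there, only 4-chlorophenyl gives the low number. Nothing available explains this difference. Still open, as far as these compounds go, is whether the low number needs the chlorine or only the ring, as a plain phenyl group could show. A methyl group at this carbon might also show whether the number depends on having a ring there at all.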